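A few compounds are considered here, and "the series" means these few. Any claim that something is new, unique, unknown or untested is made for them only; others in the source may bear on it.

Working notes on a small set of bis-hydrazone thiosemicarbazides measured in a functional assay on COS-7 cells (Chlorocebus aethiops) for inhibition, read by MTT assay; a higher number here means a weaker inhibitor, a lower number a stronger inhibitor.

Compound 1 `O=C1Nc2ccc(Br)cc2/C1=N/NC(=S)N/N=C/c1c(Cl)cccc1Cl` carries a 2,6-dichlorophenyl on the outer hydrazone carbon; in this assay compound 1 gives 6730 nM. Compound 2 `O=C1Nc2ccc(Br)cc2/C1=N/NC(=S)N/N=C/c1ccccc1Br` differs from it by the change (2-bromophenyl in place of 2,6-dichlorophenyl on a carbon with a double bond to nitrogen). For compound 2 only a limit of this assay is recorded, > 50000 nM, not a number. The change thus gives an at least 7.4-fold higher number from compound 1 to compound 2 (0.87 log units; beyond the scatter), and the true size of the step is open because of the limit of > 50000 nM in this assay, at which 1 of the 3 values shown sits.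

Compound 3 `Cc1ccc2c(c1)/C(=N/NC(=S)N/N=C/c1c(Cl)cccc1Cl)C(=O)N2` differs from compound 1 in the core, by methyl in place of bromo on an aromatic carbon; in this assay compound 3 gives 3870 nM. The step is a 1.7-fold lower number from compound 1 to compound 3 (0.24 log units; within the scatter), so the two cores are not distinguished by the present data.

Compound 4 `Cc1ccc2c(c1)/C(=N/NC(=S)N/N=C/c1ccccc1Br)C(=O)N2` is not yet measured in this assay. It differs from compound 3 by 2-bromophenyl in place of 2,6-dichlorophenyl on a carbon with a double bond to nitrogen. The place of this change reads the same as for the pair compound 1 to compound 2, so it is the same change, made this time on the core of compound 3. Since the same change from compound 1 to compound 2 gave an at least 7.4-fold higher number from compound 1 to compound 2 (0.87 log units; beyond the scatter), a step of at least that size is expected from compound 3 to compound 4, estimated as a 9.0-fold higher number from compound 3 to compound 4 (0.96 log units; beyond the scatter), with a real chance that only a limit of this assay is reported. For compound 4 the expected value in this assay is 35000 nM, estimated between 12000 nM and 100000 nM.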

Compound 4, half-maximal inhibitory concentration: > 50000 nM
Compound 4 gave a limit, no number; the forecaster's own chance of this, stated with the estimate: 40%; at least 1.4-fold (0.15 log units) between middle value and limit.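

In this assay, the change to 2-bromophenyl in place of 2,6-dichlorophenyl carries over to the core of compound 3 in the same direction, with an at least 12-fold higher number from compound 3 to compound 4 (1.11 log units; beyond the scatter), and on both cores shown the 2-bromophenyl compound ends at a limit of the assay and not at a number. Set side by side, the two steps agree in direction, but their sizes cannot be told apart: the same change on two cores in this assay, an at least 7.4-fold higher number (0.87 log units; beyond the scatter) from compound 1 to compound 2 and an at least 12-fold higher number (1.11 log units; beyond the scatter) from compound 3 to compound 4; the limit leaves it open whether they differ. Each step is known only as a lower bound, so the two cores show that the change carries over in direction and do not show that it carries over with the same size: the limit of > 50000 nM in this assay, at which 2 of the 4 values shown sit.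

On these data alone, the step from compound 2 to compound 4 cannot be read, both values being limits, so it stays open whether methyl in place of bromo on an aromatic carbon of the core matters when 2-bromophenyl is present. Also open, as far as these compounds go, is whether phenyl or 2-chlorophenyl on the carbon with a double bond to nitrogen would give a number and not a limit, and how the change would read with methoxy on the aromatic carbon of the core.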